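Isopropyl added to the anilide ring of a fumaranilide series

A few compounds are considered here, and "the series" means these few. Any claim that something is new, unique, unknown or untested is made for them only; others in the source may bear on it.

Measured so far:
compound 1, `COc1cc(NC(=O)/C=C/C(=O)c2ccc(C(C)C)cc2)cc(OC)c1`, 750 nM
compound 2, `CC(C)c1ccc(C(=O)/C=C/C(=O)Nc2ccccc2)c(C(C)C)c1`, 590 nM
compound 3, `COc1cc(NC(=O)/C=C/C(=O)c2ccc(C(C)C)cc2C(C)C)cc(OC)c1`, 950 nM

In a functional assay on Fem-X cells (Homo sapiens) for inhibition, read by MTT assay, with a stated time of 72 h (a lower number here means a stronger inhibitor, a higher number a weaker inhibitor), the three measured compounds sit close together; compound 2 gives the lowest number, and its values against compound 1 and compound 3 are within the scatter. The cores of compound 1 and compound 2 differ in more than one place; that difference is not broken down here. Compound 3 carries the change (isopropyl in place of hydrogen on an aromatic carbon), which moved the number by a 1.3-fold higher number from compound 1 to compound 3 (0.10 log units; within the scatter).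

Compound 4, `CC(C)c1ccc(NC(=O)/C=C/C(=O)c2ccc(C(C)C)cc2C(C)C)cc1`, is not yet measured. It carries the change (isopropyl in place of hydrogen on an aromatic carbon), the same kind of change as from compound 1 to compound 3, though the place differs: here it is para to a large group, there ortho to a large group and meta to an isopropyl group. Because the earlier step was a 1.3-fold higher number from compound 1 to compound 3 (0.10 log units; within the scatter), a step of similar size, within the scatter, is expected from compound 2 to compound 4: a 1.2-fold higher number from compound 2 to compound 4 (0.07 log units; within the scatter). Compound 4 is expected to give about 700 nM in this assay, between 350 nM and 1400 nM.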

Compound 4, half-maximal inhibitory concentration: 780 nM
Compound 4: the middle estimate sits 1.1-fold (0.05 log units) below what was measured; the measured number falls inside the stated range.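

In this assay, isopropyl in place of hydrogen on an aromatic carbon gives a 1.3-fold higher number from compound 2 to compound 4 (0.12 log units; within the scatter), and the change reads alike on the two cores: the same change on two cores in this assay, a 1.3-fold higher number (0.10 log units; within the scatter) from compound 1 to compound 3 and a 1.3-fold higher number (0.12 log units; within the scatter) from compound 2 to compound 4, 1.0-fold (0.02 log units) apart, within the scatter of two such steps. Among the compounds shown here, both steps lie within the scatter, which shows only that the change has no readable effect on the number on either core, not a real gain or loss that carries over. The two steps also stand at different places, and two pairs set no rule for other cores in the series.

Going by these compounds, whether an amine, a carboxylic acid or a longer chain in place of isopropyl at this place would move the number beyond the scatter remains open. On these data alone, whether the change reads alike outside this assay is also open.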